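This account rests on a few compounds, and the source may have more. Where it says the series, first, only, none or still open, it means among the compounds named here.

Working notes on the series. Of the compounds shown here, three have been measured in a physicochemical assay for lipophilicity, at pH 7.4; a lower number here means a more polar compound, a higher number a more lipophilic compound. Compound 1 `COc1cc(OC)c(NC(=O)Cn2nc(CC(=O)O)c3ccccc32)cc1Cl` gives 1.86. Compound 2 `C[C@@H](C(=O)O)c1nn(Cc2cn3cc(OCC4CC4)c(Cl)cc3n2)c2ccccc2c1=O` gives 2.41. Compound 3 `CCOc1cc2[nH]c(Cc3nn(CC(=O)N4CCOCC4)c(=O)c4ccccc34)nc2cc1Cl` gives 3.32. Compound 2 therefore holds the second highest of the three numbers in this assay: the nearest value is that of compound 1, which lies lower by a margin beyond the scatter, and the furthest is that of compound 3, which lies higher by a larger margin, also beyond the scatter. Among the measured compounds shown here, no pair of measured compounds differs in a single place, so no measured step in this assay is available to guide the next compound.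

Compound 4 `O=C(O)C1(c2nn(Cc3cn4cc(OCC5CC5)c(Cl)cc4n3)c3ccccc3c2=O)CC1` is not yet measured. It differs from compound 2 as follows: 1-carboxycyclopropyl in place of 1-carboxyethyl on an aromatic carbon. The group that enters carries one heavy atom more than the group that leaves, with the same count of donors and acceptors, so a small rise in this assay is expected, at or near the edge of the scatter. The expected step from compound 2 to compound 4 is a number 0.19 log units higher from compound 2 to compound 4 (within the scatter). Compound 4 is estimated at 2.6, within a range from 2.2 to 3.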

Compound 4, distribution coefficient: 2.46
Beside the measured number, compound 4's estimate is 0.14 log units above it, within the range that was stated.
By their numbers in this assay, from the lowest: compound 1; then compounds 2 and 4 (each within the scatter of the next); then compound 3.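

In this assay, 1-carboxycyclopropyl in place of 1-carboxyethyl on an aromatic carbon gives a number 0.05 log units higher from compound 2 to compound 4 (within the scatter), the first single-place step measured in the series. At this position, then, the open chain and the three-membered ring of carbon only cannot be told apart by this read-out, even though the change also removes the defined stereocentre of compound 2. No independent measurement bears on the reason for this result.

Both groups carry the carboxylic acid, so the compounds shown leave open how this assay responds at this position when the acid gives way to a primary amide or a methyl ester. Also open, from the compounds shown here alone, is whether a larger ring, such as 1-carboxycyclobutyl, or a longer chain carrying the acid would remain within the scatter of compound 2.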